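A Hydroxy-to-Amino Swap Starting From an Assay Limit

The source may hold more compounds than are shown below. What is called first, only, known or untested is meant among the compounds shown, and "the series" means these compounds.

In a functional assay on SGC-7901 cells (Homo sapiens) for antiproliferative activity, read by MTT assay, with a stated time of 48 h (a lower number here means a stronger inhibitor, a higher number a weaker inhibitor), compound 1 (`Cc1ccccc1-c1nnc(SCc2ccc(Cl)nc2)o1`) gives 8.51 ug/mL and compound 2 (`Clc1ccc(CSc2nnc(-c3ccccc3Cl)o2)cn1`) gives 13.5 ug/mL, two values within the scatter of each other. Compound 3 (`Oc1ccc(-c2nnc(SCc3ccc(Cl)nc3)o2)cc1`) reads > 20 ug/mL, which is a limit of the assay and not a number. Compound 4 (`Nc1ccc(-c2nnc(SCc3ccc(Cl)nc3)o2)cc1`) carries amino in place of hydroxy on an aromatic carbon. Two measured steps reach the 4-hydroxyphenyl group: an at least 2.3-fold higher number from compound 1 to compound 3 (0.37 log units; beyond the scatter), a modest one, and an at least 1.4-fold higher number from compound 2 to compound 3 (0.17 log units; that floor lies within the scatter), whose floor lies within the scatter. Neither tests amino, so they suggest no direction. The expected step is an at least 1.1-fold lower number from compound 3 to compound 4 (0.04 log units; that floor lies within the scatter), which means none beyond the scatter. The estimate for compound 4 is 18 ug/mL, with an expected range from 8 ug/mL to 40 ug/mL.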

Compound 4, half-maximal inhibitory concentration: 8.48 ug/mL
Compound 4: the middle estimate sits 2.1-fold (0.33 log units) above what was measured; the measured number falls inside the stated range.
By their numbers in this assay, from the lowest: compounds 4, 1 and 2 (each within the scatter of the next). At a limit, above all of these: compound 3.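

In this assay, amino in place of hydroxy, para to a large group, gives a change beyond the scatter, an at least 2.3-fold lower number from compound 3 to compound 4 (0.37 log units; beyond the scatter), even though both groups have the same computed hydrogen-bond donor and acceptor counts. Compound 3 stands at a limit, so this step gives only a floor: the limit of > 20 ug/mL in this assay, at which 1 of the 4 values shown sits. The 4-aminophenyl compound cannot be told apart from the two ring-substituted compounds, with a 1.6-fold lower number from compound 2 to compound 4 (0.20 log units; within the scatter) and a 1.0-fold lower number from compound 1 to compound 4 (0.00 log units; within the scatter).

Still open, on these data alone, is whether amino itself matters or whether other groups in that place would read the same. A methoxy or an acetylamino group there would test this.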